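Amide series at melanin-concentrating hormone receptor: third analogue

The source may hold more compounds than are shown below. What is called first, only, known or untested is meant among the compounds shown, and "the series" means these compounds.

Measured so far:
compound 1 `CC(C)N(C)c1ccc2cc(NC(=O)CCc3ccc(C(F)(F)F)cc3)ccc2n1` — 2 nM
compound 2 `O=C(CCc1ccc(C(F)(F)F)cc1)Nc1ccc2nc(N3CCC(c4ccccc4)C3)ccc2c1` — 25 nM

Both numbers come from an assay on isolated protein for displacement of a labelled ligand from melanin-concentrating hormone receptor 1 (Homo sapiens); a higher number here means a weaker inhibitor, a lower number a stronger inhibitor. Among the compounds with values here, compound 2 stands at the higher of the two; the only measured step is a 13-fold higher number from compound 1 to compound 2 (1.10 log units; beyond the scatter), so the bulkier substituent on that aromatic carbon went with a clear loss.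

Compound 3 `O=C(CCc1ccc(C(F)(F)F)cc1)Nc1ccc2nc(N3CCC4(CCNC4)C3)ccc2c1` differs from compound 2 as follows: a group of 9 heavy atoms (7 carbon, 2 nitrogen; 2 five-membered non-aromatic rings with 1 hetero atom each) in place of a group of 11 heavy atoms (10 carbon, 1 nitrogen; one five-membered non-aromatic ring with 1 hetero atom, one six-membered aromatic ring of carbon only), on an aromatic carbon

Within the data shown here, the one step that bears on this change, a 13-fold higher number from compound 1 to compound 2 (1.10 log units; beyond the scatter), was large; it shows the 3-phenylpyrrolidin-1-yl group costing potency relative to a small dialkylamino group. Among the measured compounds shown here, the group entering in compound 3 has no precedent, so the direction of the step is uncertain. In this assay compound 3 is therefore expected at about 30 nM, with a range from 5 nM to 200 nM. The expected step of a 1.2-fold higher number from compound 2 to compound 3 (0.08 log units; within the scatter) is thus small, possibly none beyond the scatter.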

Compound 3, half-maximal inhibitory concentration: 0.5 nM
Beside the measured number, compound 3's estimate is 60-fold (1.78 log units) above it; measured number outside the range, below it.
By their numbers in this assay, from the lowest: compound 3; then compound 1; then compound 2.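

The place next to the ring nitrogen is not limited to small dialkylamino groups: in this assay the group with 2 five-membered non-aromatic rings outperforms isopropyl(methyl)amino, with a 4.0-fold lower number from compound 1 to compound 3 (0.60 log units; beyond the scatter) as the measured step. The loss seen with 3-phenylpyrrolidin-1-yl is therefore not a general cost of a cyclic amine here, as a 50-fold lower number from compound 2 to compound 3 (1.70 log units; beyond the scatter) shows for an exchange that also brings in 1 hydrogen-bond donor. No measurement at hand bears on why the number moved.

The phenyl ring, the second ring nitrogen and the hydrogen-bond donor all change together, so the compounds shown do not separate them. A 3-aminopyrrolidin-1-yl group, or the same two-ring group with a methyl on its free ring nitrogen, would help to pull these apart.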